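Compound 2 to compound 3: a single exchange

The source may hold more compounds than are shown below. What is called first, only, known or untested is meant among the compounds shown, and "the series" means these compounds.

Compound 1 `COc1cc(OC)c(OC)cc1/C=C/COC(=O)/C=C/c1c(OC)ccc(OC)c1OC`: 212 mg/kg
Compound 2 `COc1cc(OC)c(OC)cc1/C=C/COC(=O)/C=C/c1ccccc1C(F)(F)F`: > 200 mg/kg

Both compounds were tested in a functional assay on the whole organism (strain Kunming) with Mus musculus as the target, with a stated time of 0.5 h (a higher number here means that more compound is needed for the effect, a lower number that less compound is needed), and compound 1 gives a measured number there, 212 mg/kg. Compound 2 stands at > 200 mg/kg, which is a limit of the assay and not a number.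

Compound 3 `COc1cccc(/C=C/C(=O)OC/C=C/c2cc(OC)c(OC)cc2OC)c1` differs from compound 2 in one place: 3-methoxyphenyl in place of 2-(trifluoromethyl)phenyl on a double-bonded chain carbon bound to a double-bonded chain carbon. Here 3-methoxyphenyl stands in place of 2-(trifluoromethyl)phenyl on a double-bonded chain carbon bound to a double-bonded chain carbon. Within the data shown here, no measured pair shows what such an exchange does in this assay. Only a modest move toward a lower dose is therefore expected, little beyond the scatter, and another limit would be no surprise. The expected change is an at least 1.1-fold lower number from compound 2 to compound 3 (0.07 log units; that floor lies within the scatter). For compound 3 the estimated dose is 170 mg/kg, with an expected range from 80 mg/kg to 320 mg/kg.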

Compound 3, dose for half-maximal effect: 247 mg/kg
The estimate for compound 3 lay 1.5-fold (0.16 log units) below the measured number; the measured number falls inside the stated range.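

No step can be read in this assay between compound 2 and compound 3, since the entry for compound 2 is a limit and not a number: the limit of > 200 mg/kg in this assay, at which 1 of the 3 values shown sits.

The compounds shown leave open how far, and in which direction, 3-methoxyphenyl in place of 2-(trifluoromethyl)phenyl moves the dose.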